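The source may report more compounds than this note shows. Statements on the series, on what has been measured and on what is new or still open speak of the compounds shown alone.

Working notes on the series.

Three compounds have numbers in a functional assay on A549 cells (Homo sapiens) for cytotoxicity, read by MTT assay, with a stated time of 72 h; on this read-out higher numbers stand for weaker inhibition and lower numbers for stronger inhibition. Compound 1 `Cc1c(C(=O)Nc2ccc(Oc3ccnc4[nH]ccc34)cc2)nnn1-c1ccccc1` gives 420 nM. Compound 2 `Cc1c(C(=O)Nc2ccc(Oc3ccnc4[nH]ccc34)cc2)nnn1-c1ccccc1F` gives 320 nM in this assay. Compound 3 `O=C(Nc1ccc(Oc2ccnc3[nH]ccc23)cc1)c1nnn(-c2ccccc2F)c1C(F)(F)F` gives 210 nM in this assay. Compound 3 thus carries the lowest of the three numbers, but its gaps to compound 2 and to compound 1 both sit within the scatter, so no order among the three is claimed.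

Compound 4 `O=C(Nc1ccc(Oc2ccnc3[nH]ccc23)cc1)c1nnn(-c2ccc(F)c(Cl)c2)c1C(F)(F)F` is not yet measured. It differs from compound 3 by 3-chloro-4-fluorophenyl in place of 2-fluorophenyl on an aromatic nitrogen. The steps known so far, a 1.3-fold lower number from compound 1 to compound 2 (0.12 log units; within the scatter) and a 1.5-fold lower number from compound 2 to compound 3 (0.18 log units; within the scatter), each changed a substituent on or near the same part of the molecule, and each stayed within the scatter. For the measured compounds named here, the present change swaps one substituted phenyl for another on the same aromatic nitrogen; nothing among the measured steps suggests a large shift. For compound 4 the expected step is a 1.1-fold lower number from compound 3 to compound 4 (0.02 log units; within the scatter), that is none beyond the scatter. Compound 4 is therefore estimated at 200 nM in this assay, with a range from 70 nM to 600 nM.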

Compound 4, half-maximal inhibitory concentration: 1120 nM
Compound 4: middle estimate off by 5.6-fold (0.75 log units), on the low side, outside the stated range (above it).
By their numbers in this assay, from the lowest: compounds 3, 2 and 1 (each within the scatter of the next); then compound 4.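

In this assay, for the compounds shown here, the swap of aryl group on the aromatic nitrogen gives a 5.3-fold higher number from compound 3 to compound 4 (0.73 log units; beyond the scatter) and is the only step that lies beyond the scatter, while the two earlier steps stayed within it. This position, next to the ring atom that bears a trifluoromethyl group, therefore does not treat every substituted phenyl alike, and 3-chloro-4-fluorophenyl goes with weaker inhibition than 2-fluorophenyl. Nothing available accounts for this rise.

The swap changes chlorine and fluorine together, so the compounds shown do not separate the part played by the 3-chloro from that of the 4-fluoro in the step. Also open, on these data alone, is how this position responds to a group such as methoxy on the phenyl, or to an ethyl chain in place of the phenyl.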